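Swapping a methoxy for a hydroxypyrrolidine amide on the triazole phenyl

The source may hold more compounds than are shown below. What is called first, only, known or untested is meant among the compounds shown, and "the series" means these compounds.

Measured compounds:
- compound 1 `COc1ccc(/C=C\C(=O)O)c(OCc2cn(-c3ccc(NC(C)=O)cc3)nn2)c1CC=C(C)C`: 17400 nM
- compound 3 `COc1ccc(/C=C\C(=O)O)c(OCc2cn(-c3ccc(CO)cc3)nn2)c1CC=C(C)C`: 40000 nM
- compound 2 `COc1ccccc1-n1cc(COc2c(/C=C\C(=O)O)ccc(OC)c2CC=C(C)C)nn1`: "not determined" (no result reported)

Within the data shown here, in a functional assay on T47D cells (Homo sapiens) for cytotoxicity, read by MTT assay, with a stated time of 24 h (a lower number here means a stronger inhibitor, a higher number a weaker inhibitor), compound 1 gives 17400 nM and compound 3 gives 40000 nM; the one change between them, a 2.3-fold higher number from compound 1 to compound 3 (0.36 log units; beyond the scatter), is modest. Compound 2 stands nowhere on these numbers, since in this assay compound 2 gives "not determined" (no result reported). Compound 4 `COc1ccc(/C=C\C(=O)O)c(OCc2cn(-c3ccccc3C(=O)N3CCC(O)C3)nn2)c1CC=C(C)C` differs from compound 2 by (3-hydroxypyrrolidin-1-yl)carbonyl in place of methoxy on an aromatic carbon. Among the measured compounds shown here, no measured step touches this position, and the only measured step concerns a different group, so it offers no direct guide; on the shared core, both measured values lie in a weak range. Compound 4 is therefore expected to sit near that range, estimated at 25000 nM with a range of 8000 nM to 80000 nM.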

Compound 4, half-maximal inhibitory concentration: 13400 nM
The estimate for compound 4 lay 1.9-fold (0.27 log units) above the measured number, within the range that was stated.
By their numbers in this assay, from the lowest: compounds 4 and 1 (each within the scatter of the next); then compound 3.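

Among these compounds, compound 2 has no number in this assay and the change to compound 4 gives no step that can be read. On these data alone, what the (3-hydroxypyrrolidin-1-yl)carbonyl group contributes in place of methoxy stays open. No evidence here bears on this result.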